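The source may hold more compounds than are shown below. What is called first, only, known or untested is meant among the compounds shown, and "the series" means these compounds.

Of the compounds shown here, two have been measured in an assay on CHO cells for antagonist activity at transient receptor potential cation channel subfamily V member 1 (Homo sapiens), read by FLIPR; a higher number here means a weaker inhibitor, a lower number a stronger inhibitor. Compound 1 `CC(C(=O)NCc1ccc(C(F)(F)F)nc1-c1ccc2c(c1)OCCO2)c1ccc(NS(C)(=O)=O)c(F)c1` gives 5 nM, and compound 2 `CC(C(=O)NCc1ccc(C(F)(F)F)nc1Cc1ccccc1)c1ccc(NS(C)(=O)=O)c(F)c1` gives 141 nM. Within the data shown here, compound 2 therefore stands at the highest of the two numbers, its nearest neighbour being compound 1, and the single step connecting them, a 28-fold higher number from compound 1 to compound 2 (1.45 log units; beyond the scatter), replaced the 2,3-dihydro-1,4-benzodioxin-6-yl group on an aromatic carbon with a benzyl group.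

Compound 3 `CC(C(=O)NCc1ccc(C(F)(F)F)nc1CCc1ccccc1)c1ccc(NS(C)(=O)=O)c(F)c1` is not yet measured. It differs from compound 2 by benzyl in place of phenyl on a saturated chain carbon bound to an aromatic carbon; cut one bond further out, the same difference reads benzyl to phenethyl. Among the measured compounds shown here, no measured step covers a change of this kind: the only step in hand, a 28-fold higher number from compound 1 to compound 2 (1.45 log units; beyond the scatter), swapped one ring for another on the aromatic carbon, whereas here the ring that is already there is simply carried on a longer saturated chain. The expected step from compound 2 to compound 3 in this assay is therefore a 1.1-fold higher number from compound 2 to compound 3 (0.03 log units; within the scatter), that is, nothing that can be told apart from the scatter, with a wide range to reflect how little the data say. Compound 3 is accordingly expected to give about 150 nM in this assay, estimated to fall between 40 nM and 600 nM.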

Compound 3, inhibition constant: 1.4 nM
Compound 3: the middle estimate sits 110-fold (2.03 log units) above what was measured; measured number below the stated range.
By their numbers in this assay, from the lowest: compound 3; then compound 1; then compound 2.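

In this assay, carrying the same phenyl ring on a longer saturated chain, benzyl to phenethyl, gives a 100-fold lower number from compound 2 to compound 3 (2.00 log units; beyond the scatter), so this position responds sharply to chain length even though the ring itself does not change. The earlier step left open whether a ring joined through a saturated chain was simply poorer here than one bound directly to the aromatic carbon, but phenethyl in place of 2,3-dihydro-1,4-benzodioxin-6-yl gives a 3.6-fold lower number from compound 1 to compound 3 (0.55 log units; beyond the scatter), which shows that within these three compounds a directly bound ring is not needed for the lowest number. No evidence is available to explain why this change has so large an effect.

The compounds shown leave open whether the number keeps falling with a longer chain such as 3-phenylpropyl, or whether the chain must be all carbon, as a phenoxymethyl group would test. They also leave open whether a methoxy group on the phenyl ring, or a pyridine ring in its place, would be tolerated at the end of the phenethyl chain.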